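Fluoro in place of chloro on an aromatic carbon

The source may hold more compounds than are shown below. What is called first, only, known or untested is meant among the compounds shown, and "the series" means these compounds.

Compound 1 `C#C[C@@]1(O)[C@@H](CO)O[C@@H](n2cnc3c(-c4ccc(C)cc4)ncnc32)[C@@H]1O` and compound 2 `C#C[C@@]1(O)[C@@H](CO)O[C@@H](n2cnc3c(-c4ccc(Cl)cc4)ncnc32)[C@@H]1O` share one core and differ in a single group. In a functional assay on CCRF-CEM cells (Homo sapiens) for antiproliferative activity, read by cell counting, with a stated time of 72 h (on this read-out higher numbers stand for weaker inhibition and lower numbers for stronger inhibition), compound 1 gives 154000 nM as its reading, and compound 2 gives 124000 nM as its reading. These two numbers lie within the scatter of each other, so compound 2 cannot be ranked against compound 1.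

Compound 3 `C#C[C@@]1(O)[C@@H](CO)O[C@@H](n2cnc3c(-c4ccc(F)cc4)ncnc32)[C@@H]1O` differs from compound 2 in one place: fluoro in place of chloro on an aromatic carbon. This is fluoro in place of chloro on an aromatic carbon, para to a large group.

Within the data shown here, one measured step bears on this change: a 1.2-fold lower number from compound 1 to compound 2 (0.09 log units; within the scatter), with chloro in place of methyl on an aromatic carbon. That step stays within the scatter. Among the measured compounds shown here, it is only one step, and no fluoro compound has been measured yet, so the evidence is thin. Even so, no step beyond the scatter is expected in this assay here. The expected size is a 1.0-fold higher number from compound 2 to compound 3 (0.02 log units; within the scatter) as an estimate. For compound 3 the estimated value is 130000 nM in the middle, with an expected range from 65000 nM up to 260000 nM as the likely span.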

Compound 3, half-maximal inhibitory concentration: 223000 nM
Compound 3: middle estimate off by 1.7-fold (0.23 log units), on the low side, within the range that was stated.
By their numbers in this assay, from the lowest: compounds 2, 1 and 3 (each within the scatter of the next).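

With fluoro now measured beside chloro and methyl, this place on the aromatic ring, para to a large group, has been tested with a third group. In this assay, the swap of 4-chlorophenyl to 4-fluorophenyl gives a 1.8-fold higher number from compound 2 to compound 3 (0.25 log units; within the scatter), and replacing methyl with fluoro gives a 1.4-fold higher number from compound 1 to compound 3 (0.16 log units; within the scatter). Together with the earlier step, this means that all three compounds lie within the scatter of one another, so these data cannot rank fluoro, chloro and methyl at this place, and no measured evidence bears on why their readings fall so close together.

Going by these compounds, whether a very different group at this same place, such as an amine, a carboxylic acid or a longer chain, would give a reading beyond the scatter remains open. Also open is whether the three groups would stay indistinguishable when attached to a different core, since all three compounds shown here share one core and differ only in this single group.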